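The compounds below may be only part of what the source reports. "The series", "measured", "known", "first", "only" and "open" are said of these compounds alone.

Compound 1, `CCOC(=O)c1csc2nc(-c3ccc(NC(=O)CC)cc3)cn12`, is the starting point of this step. In a functional assay on MV4-11 cells (Homo sapiens) for cytotoxicity, read by MTT assay, with a stated time of 72 h (on this read-out higher numbers stand for weaker inhibition and lower numbers for stronger inhibition), compound 1 gives 9520 nM, the highest of the two numbers shown for this series. Its nearest neighbour among the measured compounds is compound 2, `CCOC(=O)c1csc2nc(-c3ccc(NC(=O)Nc4ccc(Br)cn4)cc3)cn12`, which in this assay gives 2440 nM. Compound 3, `C=CC(=O)Nc1cccc(-c2cn3c(C(=O)OCC)csc3n2)c1`, reaches only a limit of this assay, at > 20000 nM, and that is all that can be said of it (the limit of > 20000 nM in this assay, at which 1 of the 3 values shown sits). Within the data shown here, the one measured step that bears on the present change is a 3.9-fold lower number from compound 1 to compound 2 (0.59 log units; beyond the scatter), in which a pyridinylamino group on the carbonyl carbon took the place of the ethyl group.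

Compound 4, `CCOC(=O)c1csc2nc(-c3ccc(NC(=O)Nc4ccccc4)cc3)cn12`, differs from compound 1 in the same position: anilino in place of ethyl on a carbonyl carbon. The change from an ethyl to an aryl-amino group at this carbonyl is the same kind of change that was measured between compound 1 and compound 2, though the ring that enters here is of carbon only. A step of similar character, and of modest size, is therefore expected, as a 2.7-fold lower number from compound 1 to compound 4 (0.43 log units; beyond the scatter). Compound 4 is accordingly estimated to give about 3500 nM in this assay, with a range from 1400 nM to 9000 nM.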

Compound 4, half-maximal inhibitory concentration: > 20000 nM
Compound 4 gave a limit, no number (the forecaster's own chance of this, stated with the estimate: 5%); at least 5.7-fold (0.75 log units) between middle value and limit.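

In this assay compound 4 stands at a limit and not at a number: the limit of > 20000 nM in this assay, at which 2 of the 4 values shown sit. An aryl-amino group on this carbonyl carbon therefore does not bring a lower number by itself, as anilino in place of ethyl gives an at least 2.1-fold higher number from compound 1 to compound 4 (0.32 log units; beyond the scatter), the opposite direction to a 3.9-fold lower number from compound 1 to compound 2 (0.59 log units; beyond the scatter). The ring on the amide-type nitrogen now emerges as the part that matters among these compounds, with phenyl in place of 5-bromopyridin-2-yl giving an at least 8.1-fold higher number from compound 2 to compound 4 (0.91 log units; beyond the scatter).

The compounds shown leave open whether the bromine or the ring nitrogen of 5-bromopyridin-2-yl accounts for that gap, a question that a bromophenyl group or a plain pyridin-2-yl group on the same nitrogen would address. On these data alone, how far compound 4 lies past the limit also remains unknown, so the full size of both of its steps stays open.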